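Carboxyphenyl variants and a third to come

The compounds below may be only part of what the source reports. "The series", "measured", "known", "first", "only" and "open" are said of these compounds alone.

Measured compounds:
compound 1, `COc1ccc(-c2cccc(COc3ccc4c(c3)CN(C3CCCC3)C4=O)c2)cc1C(=O)O`, 78%
compound 2, `O=C(O)c1cc(F)cc(-c2cccc(COc3ccc4c(c3)CN(C3CCCC3)C4=O)c2)c1`, 80.8%
compound 3, `Cc1ccc(C(=O)O)cc1-c1cccc(COc2ccc3c(c2)CN(C2CCCC2)C3=O)c1`, not yet measured

Both measured compounds share a core and differ only in the carboxyphenyl group on an aromatic carbon. In an assay on HEK293 cells for positive allosteric modulation of metabotropic glutamate receptor 2 (Rattus norvegicus), read by thallium flux (on this read-out lower numbers stand for smaller maximal responses and higher numbers for larger maximal responses), compound 1 gives 78% and compound 2 gives 80.8%. Compound 2 stands highest of the two numbers, but its nearest neighbour is compound 1, and the step of a number 2.8 percentage points higher from compound 1 to compound 2 (within the scatter) lies within the scatter, so the two cannot be ordered.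

Compound 3 carries the change (5-carboxy-2-methylphenyl in place of 3-carboxy-5-fluorophenyl on an aromatic carbon). Among the compounds with values here, the only measured step that bears on it is a number 2.8 percentage points higher from compound 1 to compound 2 (within the scatter), an exchange of one carboxyphenyl group for another at the same place, and it was within the scatter. On that basis the author expects the step of a number 0.8 percentage points lower from compound 2 to compound 3 (within the scatter) to stay within the scatter as well, with no direction that can be trusted. Compound 3 is therefore estimated at 80% in this assay, in a range from 66% to 92%.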

Compound 3, largest response reached (reported as percent of maximum), in percent of the reference or control that the assay uses: 80.8%
Compound 3: middle estimate off by 0.8 percentage points, on the low side; the range from low to high includes it.
By their numbers in this assay, from the lowest: compounds 1, 2 and 3 (each within the scatter of the next).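

In this assay, 5-carboxy-2-methylphenyl on this aromatic carbon gives no change at the digits printed from compound 2 to compound 3 (within the scatter) and a number 2.8 percentage points higher from compound 1 to compound 3 (within the scatter), so a third carboxyphenyl group joins the first two without separating from either. The three compounds therefore cannot be ordered, and the earlier single exchange now stands as a small set: with the carboxyphenyl group kept at this place, compounds bearing a methoxy, a fluorine or a methyl substituent on that ring all lie within the scatter of one another on this read-out of maximal response. Nothing available accounts for this result or links it to any feature of these groups.

All three compounds carry a carboxylic acid on this ring, so the compounds shown leave open whether a tetrazole, a primary amide or an amine in its place would keep the maximal response in the same range, and whether an unsubstituted phenyl would do so. They also leave open whether a larger substituent, such as a trifluoromethyl or a longer alkyl chain, on the carboxyphenyl ring would separate from these three values.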